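Nitro in place of methyl: from compound 3 to compound 4

The source may report more compounds than this note shows. Statements on the series, on what has been measured and on what is new or still open speak of the compounds shown alone.

In a functional assay on MGC-803 cells (Homo sapiens) for inhibition, read by CCK-8 assay, with a stated time of 48 h (a lower number here means a stronger inhibitor, a higher number a weaker inhibitor), compound 1 `COc1ccc(CN(C(=O)CSC(=S)N2CCN(C(=O)OC(C)(C)C)CC2)c2cc(OC)c(OC)c(OC)c2)cc1` gives 310 nM. Its bromo analogue, compound 2 `COc1ccc(CN(C(=O)CSC(=S)N2CCN(C(=O)OC(C)(C)C)CC2)c2cc(OC)c(OC)c(OC)c2)cc1Br`, gives 3710 nM.

Compound 3 `COc1ccc(CN(C(=O)CSC(=S)N2CCN(C(=O)OC(C)(C)C)CC2)c2cc(OC)c(OC)c(OC)c2)cc1C` reads > 20000 nM, which is a limit of the assay and not a number.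

Compound 3 therefore stands at the limit of > 20000 nM in this assay, at which 1 of the 3 values shown sits, and its steps place it as the weakest of the three. Compound 4 `COc1ccc(CN(C(=O)CSC(=S)N2CCN(C(=O)OC(C)(C)C)CC2)c2cc(OC)c(OC)c(OC)c2)cc1[N+](=O)[O-]` carries nitro in place of methyl on an aromatic carbon, ortho to a methoxy group: nitro in place of methyl on an aromatic carbon.

Three measured steps at this carbon bear on the change. Bromo in place of hydrogen gave a 12-fold higher number from compound 1 to compound 2 (1.08 log units; beyond the scatter), methyl in place of hydrogen gave an at least 64-fold higher number from compound 1 to compound 3 (1.80 log units; beyond the scatter), and methyl in place of bromo gave an at least 5.3-fold higher number from compound 2 to compound 3 (0.73 log units; beyond the scatter). Both substituents lost ground from compound 1, which gives 310 nM, so compound 4 is expected to be a weaker inhibitor than compound 1. Methyl was the poorer of the two, so a result nearer compound 2 at 3710 nM is expected.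

The expected change is an at least 5.0-fold lower number from compound 3 to compound 4 (0.69 log units; beyond the scatter), towards a lower number, though it could prove small. Compound 4 is estimated at 4000 nM, within a range of 800 nM to 20000 nM.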

Compound 4, half-maximal inhibitory concentration: 880 nM
The estimate for compound 4 lay 4.5-fold (0.66 log units) above the measured number; low and high end bracket the measured number.
By their numbers in this assay, from the lowest: compound 1; then compound 4; then compound 2. At a limit, above all of these: compound 3.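

Nitro has more heavy atoms than methyl, yet exchanging one for the other gave an at least 22-fold lower number from compound 3 to compound 4 (1.35 log units; beyond the scatter), so heavy-atom count alone does not set the order at this carbon. Nitro also improved on bromo, with a 4.2-fold lower number from compound 2 to compound 4 (0.62 log units; beyond the scatter), while hydrogen stayed ahead of nitro, with a 2.8-fold higher number from compound 1 to compound 4 (0.45 log units; beyond the scatter), leaving compound 1 as the strongest of the four and showing that none of the three substituents matched hydrogen here. The methyl step still gives only a bound, since compound 3 remains at a limit of the assay and not a number: the limit of > 20000 nM in this assay, at which 1 of the 4 values shown sits.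

The compounds shown do not tell why nitro is better tolerated than bromo or methyl. As far as these compounds go, whether an amine, a hydroxyl or a carboxylic acid at this carbon would match or surpass compound 1 also remains open.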